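The source may report more compounds than this note shows. Statements on the series, on what has been measured and on what is new or still open speak of the compounds shown alone.

Measured so far:
- compound 1 `NC1CCC(Nc2nc(NCc3ccc(-c4ccccc4)cc3)c3ncn(C4CCCC4)c3n2)CC1`: 745 nM
- compound 2 `NC1CCC(Nc2nc(NCc3ccc(-c4cccs4)nc3)c3ncn(C4CCCC4)c3n2)CC1`: 97 nM
- compound 3 `NC1CCC(Nc2nc(NCc3ccc(-c4ccsc4)nc3)c3ncn(C4CCCC4)c3n2)CC1`: 145 nM

In a functional assay on HCT-116 cells (Homo sapiens) for inhibition, with a stated time of 72 h (a lower number here means a stronger inhibitor, a higher number a weaker inhibitor), compound 1 has the highest number of the three, at 745 nM. Compound 4 `NC1CCC(Nc2nc(NCc3ccc(-c4ccccc4O)cc3)c3ncn(C4CCCC4)c3n2)CC1` is compound 1 with one change, phenyl to 2-hydroxyphenyl: hydroxy in place of hydrogen on an aromatic carbon. The hydroxy replaces hydrogen on an aromatic carbon, ortho to a large group.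

Among the measured compounds shown here, no measured step adds a hydroxy. The closest are a 7.7-fold lower number from compound 1 to compound 2 (0.89 log units; beyond the scatter) and a 5.1-fold lower number from compound 1 to compound 3 (0.71 log units; beyond the scatter), which replace the whole 4-phenylphenyl group. Moving the thiophene attachment gave a 1.5-fold higher number from compound 2 to compound 3 (0.17 log units; within the scatter). These steps offer only indirect guidance, so no shift beyond the scatter is expected in this assay.

The expected change is a 1.4-fold lower number from compound 1 to compound 4 (0.13 log units; within the scatter). For compound 4 the estimated value is 550 nM, with an expected range of 200 nM to 1500 nM.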

Compound 4, half-maximal inhibitory concentration: 4350 nM
Beside the measured number, compound 4's estimate is 7.9-fold (0.90 log units) below it, and the stated range ends below it.
By their numbers in this assay, from the lowest: compounds 2 and 3 (each within the scatter of the next); then compound 1; then compound 4.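

A single hydroxy on an aromatic carbon, ortho to a large group, gives a 5.8-fold higher number from compound 1 to compound 4 (0.77 log units; beyond the scatter) in this assay. The earlier steps shown here replaced the whole 4-phenylphenyl group and lowered the number, whereas this step shows that adding 1 heavy atom to the phenyl of compound 1 can raise it beyond the scatter. No measurement shown here explains the rise. Going by these compounds, whether the rise is specific to hydroxy or extends to other groups at this place remains open. A methoxy or an amine there would test this.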